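Title: Swapping butyl for tert-butyl on a sulfonamide acid

This account rests on a few compounds, and the source may have more. Where it says the series, first, only, none or still open, it means among the compounds named here.

Measured so far:
compound 1, `CC(C)(C)c1ccc(CN(Cc2cccc(CCC(=O)O)c2)S(=O)(=O)c2nccs2)cc1`, 63 nM
compound 2, `CCCCc1ccc(CN(Cc2cccc(CCC(=O)O)c2)S(C)(=O)=O)cc1`, 270 nM

Both compounds were tested in an assay on HEK293 cells for inhibition of prostaglandin E2 receptor EP2 subtype (Rattus norvegicus); a lower number here means a stronger inhibitor, a higher number a weaker inhibitor. Compound 1 gives 63 nM, and compound 2 gives 270 nM, the higher of the two numbers and therefore the weaker inhibitor of the pair; the gap between them is beyond the usual scatter. Compound 1 differs from compound 2 in more than one part of the molecule, so it cannot tell on its own which part drives that gap.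

The next compound, compound 3, `CC(C)(C)c1ccc(CN(Cc2cccc(CCC(=O)O)c2)S(C)(=O)=O)cc1`, is not yet measured. It differs from compound 2 in a single place: tert-butyl in place of butyl on an aromatic carbon. The same atoms are present in both, only joined differently, and the change sits on the aromatic ring far from the acid chain.

For the measured compounds named here, no measured pair isolates this change, so the direction of the step is uncertain, and a modest improvement or no change beyond the scatter is the most plausible outcome. The expected step is estimated as a 1.5-fold lower number from compound 2 to compound 3 (0.18 log units; within the scatter). Compound 3 is therefore estimated at 180 nM, with a likely range from 60 nM to 500 nM.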

Compound 3, half-maximal inhibitory concentration: 379 nM
Compound 3: the middle estimate sits 2.1-fold (0.32 log units) below what was measured; the measured number falls inside the stated range.
By their numbers in this assay, from the lowest: compound 1; then compounds 2 and 3 (each within the scatter of the next).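

In this assay, tert-butyl in place of butyl on the aromatic ring gives a 1.4-fold higher number from compound 2 to compound 3 (0.15 log units; within the scatter), so with methyl on the sulfonyl sulfur, the branched and straight four-carbon groups cannot be told apart at this position. Compound 3 also provides the comparison that was missing earlier, because it differs from compound 1 in one place only: methyl in place of 1,3-thiazol-2-yl on the sulfonyl sulfur gives a 6.0-fold higher number from compound 1 to compound 3 (0.78 log units; beyond the scatter), a real loss of inhibition in this pair. The gap between compound 1 and compound 2, which could not be assigned to either part of the molecule before, can therefore now be linked mainly to the sulfonyl substituent, although no data here explain why either step has the size it does.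

From the compounds shown here alone, it remains open whether butyl and tert-butyl would also match when 1,3-thiazol-2-yl sits on the sulfonyl sulfur, since only tert-butyl appears with that group here. Also open, going by these compounds, is how other groups would behave, such as a phenyl ring or an ethyl group on the sulfonyl sulfur, or a methoxy group or a chlorine atom in place of tert-butyl on the aromatic ring.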